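From Sec-Butyl to Heptyl on a Shared Core

The compounds below may be only part of what the source reports. "The series", "measured", "known", "first", "only" and "open" are said of these compounds alone.

Three measured compounds share one core and differ in the chain on a double-bonded nitrogen: compound 1 `C[C@@H](/N=c1\c(O)c(O)\c1=N/c1ccc(C#N)cc1)C(C)(C)C`, compound 2 `CC(C)C(C)/N=c1\c(O)c(O)\c1=N/c1ccc(C#N)cc1` and compound 3 `CCC(C)/N=c1\c(O)c(O)\c1=N/c1ccc(C#N)cc1`. In a functional assay for inhibition, with Rattus norvegicus as the target (a higher number here means a weaker inhibitor, a lower number a stronger inhibitor), compound 3 gives 2100 nM and compound 2 gives 1900 nM, so the two stand level within the scatter. Compound 1 gives 370 nM; 24300 nM (2 entries), two entries far apart, and the number for compound 3 falls between them.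

The open question is compound 4 `CCCCCCC/N=c1\c(O)c(O)\c1=N/c1ccc(C#N)cc1`, which has heptyl in place of sec-butyl on a double-bonded nitrogen. Among the measured compounds shown here, only one measured step bears on this chain, a swap of methyl for hydrogen, and it was small: a 1.1-fold higher number from compound 2 to compound 3 (0.04 log units; within the scatter). That swap is a much smaller structural change than the one at hand, so it guides the expectation only loosely. The spread in the several entries of compound 1 in this assay, 370 nM; 24300 nM (2 entries) also shows how far apart two readings can lie in this assay, which argues for a wide range. Going by that small step, no change beyond the scatter is expected, and the estimate is a 1.4-fold higher number from compound 3 to compound 4 (0.15 log units; within the scatter). For compound 4 the expected value is 3000 nM, with an estimated range from 500 nM to 18000 nM.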

Compound 4, half-maximal inhibitory concentration: > 30000 nM
Compound 4: only a limit was reported; the forecaster's own chance of this, stated with the estimate: 10%; middle value at least 10-fold (1.00 log units) from the limit.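

Replacing sec-butyl with heptyl on a double-bonded nitrogen has a large effect in this assay: an at least 14-fold higher number from compound 3 to compound 4 (1.15 log units; beyond the scatter), and an at least 15-fold higher number from compound 2 to compound 4 (1.19 log units; beyond the scatter). Compound 4 is reported only as a limit, > 30000 nM, so both steps give a minimum size, and its true number could lie further off. Among the compounds shown here, the only earlier step at this position, a 1.1-fold higher number from compound 2 to compound 3 (0.04 log units; within the scatter), stayed within the scatter, whereas heptyl shows that a change to this chain can weaken inhibition well beyond it.

Heptyl differs from sec-butyl in both length and branching, and the compounds shown cannot separate the two, which a straight butyl chain would help to do. The place of compound 1 in this series also stays unsettled, since its two readings lie far apart: the several entries of compound 1 in this assay, 370 nM; 24300 nM (2 entries)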